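Methoxy for methyl, tried on a second core

The compounds below may be only part of what the source reports. "The series", "measured", "known", "first", "only" and "open" are said of these compounds alone.

Measured so far in a functional assay on PC-3 cells (Homo sapiens) for inhibition, read by MTT assay, with a stated time of 48 h; a lower number here means a stronger inhibitor, a higher number a weaker inhibitor:
compound 1, `Cc1ccc(/C=C2\SC(=O)N(CCNC(=O)Nc3c(C)n(C)n(-c4ccccc4)c3=O)C2=O)cc1`, gives 58700 nM
compound 2, `COc1ccc(/C=C2\SC(=O)N(CCNC(=O)Nc3c(C)n(C)n(-c4ccccc4)c3=O)C2=O)cc1`, gives 13900 nM
compound 3, `Cc1ccc(/C=C2\SC(=O)N(CC(=O)Nc3c(C)n(C)n(-c4ccccc4)c3=O)C2=O)cc1`, gives 45300 nM

Compound 1 and compound 2 differ in one place, (methoxy in place of methyl on an aromatic carbon), and this single change gave a 4.2-fold lower number from compound 1 to compound 2 (0.63 log units; beyond the scatter) in this assay. Compound 3 carries a different core; how the core of compound 3 differs from that of compound 1 is not broken down here. In this assay the numbers for compound 3 and compound 1 lie within the scatter of each other, so no order between them is claimed; compound 2 stands apart from both.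

Compound 4, `COc1ccc(/C=C2\SC(=O)N(CC(=O)Nc3c(C)n(C)n(-c4ccccc4)c3=O)C2=O)cc1`, is not yet measured. It differs from compound 3 by methoxy in place of methyl on an aromatic carbon, which is the same change as that from compound 1 to compound 2, with the same words describing its place. Among the four compounds this change occurs twice, once measured and once to be measured.

The expectation for compound 4 rests on one precedent only. Because compound 1 to compound 2 gave a 4.2-fold lower number from compound 1 to compound 2 (0.63 log units; beyond the scatter), a step of a similar size is expected from compound 3 to compound 4, namely a 3.5-fold lower number from compound 3 to compound 4 (0.54 log units; beyond the scatter), with wide bounds since the core is different and a single step is a thin basis. Compound 4 is therefore estimated at 13000 nM in this assay, expected to fall between 5000 nM and 40000 nM.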

Compound 4, half-maximal inhibitory concentration: 93700 nM
For compound 4 the middle estimate is 7.2-fold (0.86 log units) below the measured one, and the stated range ends below it.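

In this assay, methoxy in place of methyl on an aromatic carbon gave a 2.1-fold higher number from compound 3 to compound 4 (0.32 log units; beyond the scatter), so the lower number seen on the core of compound 1 did not recur on the core of compound 3. The same 4-methylphenyl to 4-methoxyphenyl change therefore behaves differently on the two cores: the same change on two cores in this assay, a 4.2-fold lower number (0.63 log units; beyond the scatter) from compound 1 to compound 2 and a 2.1-fold higher number (0.32 log units; beyond the scatter) from compound 3 to compound 4, 8.7-fold (0.94 log units) apart, beyond the scatter of two such steps. Going by these compounds alone, this shows that, within these four compounds, a step measured on one core cannot be carried over to the other, even in direction; it does not show which feature of the cores is responsible, and with only one pair on each core it gives no rule for the series.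

The compounds shown leave open how other groups on the same aromatic carbon, such as hydroxy, chloro or dimethylamino, would behave on each core, and whether any of them would give steps that agree between the two cores. They also leave open whether the change from methyl to methoxy would follow the core of compound 1 or the core of compound 3 on a further core, for instance one carrying a longer chain on the ring nitrogen.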